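Working notes: tert-butoxycarbonyl in place of benzyl

The source may hold more compounds than are shown below. What is called first, only, known or untested is meant among the compounds shown, and "the series" means these compounds.

- Compound 1 `COc1ccc(-c2coc3cc(OCCCCSC(=S)N4CCN(C(=O)OC(C)(C)C)CC4)ccc3c2=O)cc1` gives 31300 nM
- Compound 2 `COc1ccc(-c2coc3cc(OCCCSC(=S)N4CCN(Cc5ccccc5)CC4)ccc3c2=O)cc1` gives 43800 nM
- Compound 3 `COc1ccc(-c2coc3cc(OCCCSC(=S)N4CCCC4)ccc3c2=O)cc1` gives 40000 nM

In a functional assay on MGC-803 cells (Homo sapiens) for inhibition, read by MTT assay, with a stated time of 48 h (on this read-out higher numbers stand for weaker inhibition and lower numbers for stronger inhibition), compound 2 gives 43800 nM and stands within the scatter of both compound 3 and compound 1, so the three numbers show no order. Compound 4 `COc1ccc(-c2coc3cc(OCCCSC(=S)N4CCN(C(=O)OC(C)(C)C)CC4)ccc3c2=O)cc1` is unmeasured and has tert-butoxycarbonyl in place of benzyl on an amine nitrogen in a ring. No step beyond the scatter is expected in this assay for this change. Compound 1 also carries tert-butoxycarbonyl and gives 31300 nM within the scatter of compound 2. The expected size is a 1.2-fold lower number from compound 2 to compound 4 (0.09 log units; within the scatter) as an estimate only. For compound 4 the estimate is 36000 nM with an expected range of 18000 nM to 70000 nM for now.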

Compound 4, half-maximal inhibitory concentration: 6070 nM
For compound 4 the middle estimate is 5.9-fold (0.77 log units) above the measured one, outside the stated range (below it).
By their numbers in this assay, from the lowest: compound 4; then compounds 1, 3 and 2 (each within the scatter of the next).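

In this assay, among these compounds, this position responds to the group it carries: tert-butoxycarbonyl in place of benzyl on an amine nitrogen in a ring gives a 7.2-fold lower number from compound 2 to compound 4 (0.86 log units; beyond the scatter), the first step beyond the scatter. Compound 1 carries tert-butoxycarbonyl on a different chain and gives 31300 nM, so the group does not bring the lower number of compound 4 on every chain. Nothing at hand explains the step.

Still open, going by these compounds, is whether the step belongs to tert-butoxycarbonyl alone or extends to an acetyl group or a methyl carbamate at this nitrogen. A free ring amine at the same place would show what the unsubstituted nitrogen gives.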